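The source may hold more compounds than are shown below. What is called first, only, known or untested is meant among the compounds shown, and "the series" means these compounds.

The study concerns two measured compounds and one not yet measured, all built on a shared core. Compound 1 `Cc1cccc(COc2ccc(-c3cc(CN4CCN(Cc5ccc(C(F)(F)F)cc5)CC4)no3)cc2)c1` carries a 3-methylphenyl group on a saturated chain carbon bound to an oxygen on an aromatic ring, and in a functional assay on Huh-7 cells (Homo sapiens) for antiproliferative activity, read by sulforhodamine B assay, with a stated time of 72 h (on this read-out lower numbers stand for stronger inhibition and higher numbers for weaker inhibition), compound 1 gives 5000 nM. Among the compounds with values here, compound 2 `Fc1ccc(COc2ccc(-c3cc(CN4CCN(Cc5ccc(C(F)(F)F)cc5)CC4)no3)cc2)cc1` has 4-fluorophenyl at that place, and in this assay compound 2 gives 2000 nM, the lowest of the two numbers; the single step between them, a 2.5-fold lower number from compound 1 to compound 2 (0.40 log units; beyond the scatter), is modest but beyond the scatter. Compound 3 `COc1cc(COc2ccc(-c3cc(CN4CCN(Cc5ccc(C(F)(F)F)cc5)CC4)no3)cc2)cc(OC)c1` differs from compound 2 in one place: 3,5-dimethoxyphenyl in place of 4-fluorophenyl on a saturated chain carbon bound to an oxygen on an aromatic ring. Within the data shown here, only one measured step bears on this change, because it sits at the same place: a 2.5-fold lower number from compound 1 to compound 2 (0.40 log units; beyond the scatter). Among the measured compounds shown here, no measured compound carries a ring with two methoxy groups, so the direction of the new step is not anchored by the data. A step of similar size in either direction, or none beyond the scatter, is therefore expected in this assay, corresponding to a 1.5-fold higher number from compound 2 to compound 3 (0.18 log units; within the scatter). Compound 3 is accordingly estimated at 3000 nM, expected to fall within 1000 nM to 10000 nM.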

Compound 3, half-maximal inhibitory concentration: 1500 nM
Estimate against measurement, compound 3: 2.0-fold (0.30 log units) above; measured number inside the range.
By their numbers in this assay, from the lowest: compounds 3 and 2 (each within the scatter of the next); then compound 1.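

In this assay, exchanging 4-fluorophenyl for 3,5-dimethoxyphenyl on a saturated chain carbon bound to an oxygen on an aromatic ring adds heavy atoms and 2 hydrogen-bond acceptors, yet the result is a 1.3-fold lower number from compound 2 to compound 3 (0.12 log units; within the scatter) and the two compounds cannot be told apart. Set against 3-methylphenyl, the same group gives a 3.3-fold lower number from compound 1 to compound 3 (0.52 log units; beyond the scatter) and this modest step lies beyond the scatter, so two quite different rings at this place now stand apart from the 3-methylphenyl of compound 1, while the larger substituted ring of compound 3 shows no loss against compound 2. No measurement available here accounts for either step.

As far as these compounds go, whether a ring with a single methoxy group, or one carrying an amine or a carboxylic acid, would move the number beyond the scatter at this place remains open. All three compounds also differ only at this one place, so what a change elsewhere on the shared core would do in this assay is left open as well.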